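A 4-methylphenyl to 4-methoxyphenyl step from compound 2

This account rests on a few compounds, and the source may have more. Where it says the series, first, only, none or still open, it means among the compounds named here.

In a functional assay on HepG2 cells (Homo sapiens) for antiproliferative activity, read by MTT assay, with a stated time of 72 h (on this read-out higher numbers stand for weaker inhibition and lower numbers for stronger inhibition), compound 1 `CCC(=O)NNC(=O)c1csc2ncc(-c3ccc(C)cc3)n12` gives 7340 nM and compound 2 `CCCC(=O)NNC(=O)c1csc2ncc(-c3ccc(C)cc3)n12` gives 26800 nM as the higher of the two numbers, which places compound 2 on the side of weaker inhibition. For the measured compounds named here, the one measured step is a 3.7-fold higher number from compound 1 to compound 2 (0.56 log units; beyond the scatter) and comes with methyl in place of hydrogen on a saturated chain carbon, two bonds along the chain from a carbonyl carbon.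

Compound 3 `CCCC(=O)NNC(=O)c1csc2ncc(-c3ccc(OC)cc3)n12` keeps that chain and the shared core. The change from compound 2 is methoxy in place of methyl on an aromatic carbon and in words it is methoxy in place of methyl on an aromatic carbon, para to a large group. Going by the values given here, no measured compound shows a change at that carbon. The step of a 3.7-fold higher number from compound 1 to compound 2 (0.56 log units; beyond the scatter) lies on the chain and offers no direct guide here, so no shift beyond the scatter is expected in this assay and no direction is favoured. The estimated move is a 1.3-fold lower number from compound 2 to compound 3 (0.13 log units; within the scatter) and remains small. Compound 3 is expected at 20000 nM with an estimated range of 7000 nM to 60000 nM for this measurement.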

Compound 3, half-maximal inhibitory concentration: 38000 nM
Estimate against measurement, compound 3: 1.9-fold (0.28 log units) below, and the stated range covers the measured number.
By their numbers in this assay, from the lowest: compound 1; then compounds 2 and 3 (each within the scatter of the next).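

For the compounds shown here, this is the first reading at this aromatic carbon, and in this assay the exchange of 4-methylphenyl for 4-methoxyphenyl gives a 1.4-fold higher number from compound 2 to compound 3 (0.15 log units; within the scatter). The swap adds one heavy atom, an oxygen, and one hydrogen-bond acceptor, yet on the chain of compound 2 it leaves the number within the scatter, so this position, unlike the chain change in a 3.7-fold higher number from compound 1 to compound 2 (0.56 log units; beyond the scatter), shows no measurable response among the compounds shown, although a single pair cannot say how this carbon behaves in general. No experimental evidence is available here to explain why this exchange leaves the reading within the scatter. The compounds shown leave open whether 4-methoxyphenyl would read the same way on the chain of compound 1, where the numbers start from a different level, since the only step at this carbon belongs to the chain of compound 2. They also leave open how an amine, a carboxylic acid or a chlorine at this same carbon would read in this assay, and so whether any group placed here can move the number beyond the scatter.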